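The source may report more compounds than this note shows. Statements on the series, on what has been measured and on what is new or still open speak of the compounds shown alone.

Measured in a functional assay on NCI-H460 cells (Homo sapiens) for cytotoxicity, read by MTT assay, with a stated time of 72 h; a lower number here means a stronger inhibitor, a higher number a weaker inhibitor:

Compound 1 `CN(C)Cc1ccc2nc(NC(=O)N/N=C3\C(=O)Nc4ccc(F)cc43)sc2c1` gives 1550 nM
Compound 2 `CCN(CC)Cc1ccc2nc(NC(=O)N/N=C/c3cn(Cc4ccc(Cl)cc4)c4ccccc34)sc2c1` gives 370 nM
Compound 3 `CN(C)Cc1ccc2nc(NC(=O)N/N=C/c3cn(Cc4ccc(Cl)cc4)c4ccccc34)sc2c1` gives 290 nM

Compound 2 is the starting point here. Compound 2 stands at 370 nM and has one close neighbour. The number of compound 1 is clearly higher than that of compound 2. For the measured compounds named here, the close neighbour is reached by a 1.3-fold lower number from compound 2 to compound 3 (0.11 log units; within the scatter), which is the only measured step that changes a single place.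

Compound 4 `CCN(CC)Cc1ccc2nc(NC(=O)N/N=C/c3cn(Cc4ccccc4)c4ccccc34)sc2c1` has not yet been measured. It differs from compound 2 by one change, (hydrogen in place of chloro on an aromatic carbon), which turns the 4-chlorobenzyl group into benzyl. Going by the values given here, no measured step touches this place, so the data offer no direct guide. The nearest evidence is a 1.3-fold lower number from compound 2 to compound 3 (0.11 log units; within the scatter), a change made at a different place, and it says only that one small edit in this series left the number within the scatter. In this assay a modest step is therefore expected, with only a slight and uncertain lean towards a higher number. The expected change is a 1.3-fold higher number from compound 2 to compound 4 (0.11 log units; within the scatter), which is an estimate and not a measurement. For compound 4 the estimated value is 480 nM, with an expected range from 190 nM to 1200 nM.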

Compound 4, half-maximal inhibitory concentration: 450 nM
For compound 4 the middle estimate is 1.1-fold (0.03 log units) above the measured one, within the range that was stated.
By their numbers in this assay, from the lowest: compounds 3, 2 and 4 (each within the scatter of the next); then compound 1.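

In this assay, for the compounds shown here, turning the 4-chlorobenzyl group into benzyl gives a 1.2-fold higher number from compound 2 to compound 4 (0.09 log units; within the scatter), and this is the first reading at this position on the aromatic ring. It shows that, for this pair, the single chlorine atom can be replaced by hydrogen without a difference this assay can tell apart from ordinary repeat scatter, so the chloro is not required for a value in this range. No other measurement here bears on this result, so the data do not explain why the two compounds read alike.

From the compounds shown here alone, only chloro and hydrogen are compared at this position, so it remains open whether a larger or quite different group there, such as methoxy, a nitrile or a carboxylic acid, would also leave the number within the scatter. Going by these compounds, it also remains open whether the same exchange of chloro for hydrogen would read alike on compound 3, which carries the dimethylamino group in place of diethylamino.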